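Swapping 3-methoxyphenyl for 3,4-difluorophenyl in compound 2

A few compounds are considered here, and "the series" means these few. Any claim that something is new, unique, unknown or untested is made for them only; others in the source may bear on it.

Going by the values given here, only two compounds have a measured value so far. In a functional assay on HT-29 cells (Homo sapiens) for antiproliferative activity, read by sulforhodamine B assay, with a stated time of 48 h (a lower number here means a stronger inhibitor, a higher number a weaker inhibitor), compound 1 (`COc1cccc(OS(=O)(=O)c2ccc(N3CCN(C)C3=O)cc2)c1`) gives 2500 nM as its reading. Compound 2 (`CCCCN1CCN(c2ccc(S(=O)(=O)Oc3cccc(OC)c3)cc2)C1=O`) gives 13000 nM and so holds the higher number of the pair, which makes it the weaker inhibitor of the two. Among the compounds with values here, the one measured step is a 5.2-fold higher number from compound 1 to compound 2 (0.72 log units; beyond the scatter) and it comes from propyl in place of hydrogen on a saturated chain carbon.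

Compound 3 (`CCCCN1CCN(c2ccc(S(=O)(=O)Oc3ccc(F)c(F)c3)cc2)C1=O`) keeps the chain of compound 2 and instead carries 3,4-difluorophenyl in place of 3-methoxyphenyl on an oxygen. The measured step lies at a different place, so it gives no direct guide to the size or direction of this change. Without such a guide, the best anchor is compound 2 at 13000 nM and no step beyond the usual scatter is confidently expected. The expected step is a 1.2-fold lower number from compound 2 to compound 3 (0.07 log units; within the scatter) in this assay with its direction left open. For compound 3 the estimated value is 11000 nM with an expected range from 4000 nM to 35000 nM as its span.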

Compound 3, half-maximal inhibitory concentration: > 100000 nM
Compound 3: no number, only a limit; the forecaster's own chance of this, stated with the estimate: 12%; middle value at least 9.0-fold (0.95 log units) from the limit.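

Changing the group on the oxygen whose other neighbour is the sulfonyl sulfur gives an at least 7.6-fold higher number from compound 2 to compound 3 (0.88 log units; beyond the scatter) in this assay, so the group held at this place clearly affects the reading. The earlier step showed this only for the chain at the other end of the molecule, while this pair shows that the aromatic group on the oxygen counts too, and that 3-methoxyphenyl gives the stronger inhibitor of these two. The reading for compound 3 is a limit and not a number, so the step has a lower bound but no known full size: the limit of > 100000 nM in this assay, at which 1 of the 3 values shown sits.

The change removes a methoxy group and adds two fluorines in a single move, so this pair cannot show which part of the swap goes with the higher number, and a plain phenyl or a phenyl carrying only one fluorine would separate the two. Also open, on these data alone, is whether 3,4-difluorophenyl would behave the same way on the shorter chain of compound 1, and whether a group such as an amine or a carboxylic acid on this aromatic ring would be tolerated.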